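The source may report more compounds than this note shows. Statements on the series, on what has been measured and on what is new or still open speak of the compounds shown alone.

Measured compounds:
- compound 1, `c1ccc(CN2CCN(CCCc3c[nH]c4ccc(-n5cnnc5)cc34)CC2)nc1`: 18 nM
- compound 2, `CC(=O)Nc1ccc(CN2CCN(CCCc3c[nH]c4ccc(-n5cnnc5)cc34)CC2)cc1`: 56 nM
- compound 3, `FC(F)(F)c1ccc(CN2CCN(CCCc3c[nH]c4ccc(-n5cnnc5)cc34)CC2)cc1`: 282 nM

In an assay on CHO cells for displacement of a labelled ligand from 5-hydroxytryptamine receptor 1B (Homo sapiens) (a lower number here means a stronger inhibitor, a higher number a weaker inhibitor), compound 1 gives the lowest of the three numbers; its nearest neighbour is compound 2, at a 3.1-fold higher number from compound 1 to compound 2 (0.49 log units; beyond the scatter), and the furthest is compound 3, at a 16-fold higher number from compound 1 to compound 3 (1.19 log units; beyond the scatter). Between those two, a 5.0-fold higher number from compound 2 to compound 3 (0.70 log units; beyond the scatter). Compound 4, `c1ccc(N2CCN(CCCc3c[nH]c4ccc(-n5cnnc5)cc34)CC2)cc1`, has not yet been measured. It differs from compound 1 in one place: phenyl in place of (pyridin-2-yl)methyl on an amine nitrogen in a ring. Among the measured compounds shown here, both measured steps from compound 1 alter the group on this same ring nitrogen, and both moved the number upward, one modestly and one by a large amount; neither, however, removes the saturated chain carbon between the ring nitrogen and the aromatic ring, so no step bears directly on the change to compound 4. For the measured compounds named here, what the measured steps show is that any departure from compound 1 at this position so far weakened binding. A modest upward step is therefore expected, a 3.3-fold higher number from compound 1 to compound 4 (0.52 log units; beyond the scatter), with wide uncertainty. For compound 4 the estimate is 60 nM, with a range from 15 nM to 250 nM.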

Compound 4, half-maximal inhibitory concentration: 13 nM
For compound 4 the middle estimate is 4.6-fold (0.66 log units) above the measured one; measured number outside the range, below it.
By their numbers in this assay, from the lowest: compounds 4 and 1 (each within the scatter of the next); then compound 2; then compound 3.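

In this assay, this step removes the saturated chain carbon and the ring nitrogen of the aromatic ring together, yet compound 4 and compound 1 cannot be told apart (a 1.4-fold lower number from compound 1 to compound 4 (0.14 log units; within the scatter)). The earlier compounds had shown only weaker binding on leaving compound 1 at this ring nitrogen, whereas this result shows that such a departure need not cost binding. The steps from the two substituted benzyl compounds (a 22-fold lower number from compound 3 to compound 4 (1.34 log units; beyond the scatter); a 4.3-fold lower number from compound 2 to compound 4 (0.63 log units; beyond the scatter)) also show that the higher numbers of compound 2 and compound 3 do not extend to phenyl on this nitrogen.

An unsubstituted benzyl group, or pyridin-2-yl placed directly on the ring nitrogen, would be needed to separate the two parts of this change, and the compounds shown include neither. No available evidence accounts for these results.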